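A few compounds are considered here, and "the series" means these few. Any claim that something is new, unique, unknown or untested is made for them only; others in the source may bear on it.

Working notes on the shared core, read in a functional assay on HCT-116 cells (Homo sapiens) for inhibition, read by MTT assay, with a stated time of 72 h; on this read-out lower numbers stand for stronger inhibition of growth and higher numbers for weaker inhibition of growth. Among the measured compounds shown here, compound 2 `CCOC(=O)/C=C/c1ccncc1-c1ccc2ccccc2c1` gives 910 nM, the lowest number so far. Compound 3 `CNC(=O)CCc1ccncc1-c1ccc2ccccc2c1` gives 19300 nM. Compound 1 `CN1CCN(C(=O)/C=C/c2ccncc2-c2ccc3ccccc3c2)CC1` reports only a limit, > 30000 nM.

The next change leads to compound 4 `COC1CN(C(=O)/C=C/c2ccncc2-c2ccc3ccccc3c2)C1`: 3-methoxyazetidin-1-yl in place of ethoxy on a carbonyl carbon, (3-methoxyazetidin-1-yl in place of ethoxy on a carbonyl carbon).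

For the measured compounds named here, two measured steps bear on it. The closer is an at least 32-fold lower number from compound 1 to compound 2 (1.51 log units; beyond the scatter), which involves the same carbonyl carbon and rests on (the limit of > 30000 nM in this assay, at which 1 of the 3 values shown sits). The other is a 21-fold higher number from compound 2 to compound 3 (1.33 log units; beyond the scatter), which also replaces the ethoxycarbonyl end but alters the chain as well. Both amides, compound 1 and compound 3, sit far from compound 2, so a large step to a higher number is expected in this assay. Compound 3, at 19300 nM, gives a number rather than a limit, so the expected step is kept within that order of size. The estimate corresponds to an expected 7.7-fold higher number from compound 2 to compound 4 (0.89 log units; beyond the scatter). For compound 4 the estimated value is 7000 nM, with an expected range of 1500 nM to 30000 nM.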

Compound 4, concentration for 50% growth inhibition: > 30000 nM
Compound 4: a limit, no number; the forecaster's own chance of this, stated with the estimate: 25%; at least 4.2-fold (0.63 log units) between middle value and limit.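

In this assay the change to 3-methoxyazetidin-1-yl gives an at least 32-fold higher number from compound 2 to compound 4 (1.51 log units; beyond the scatter). Both ring-bearing groups shown on this carbonyl carbon, 4-methylpiperazin-1-yl in compound 1 and 3-methoxyazetidin-1-yl in compound 4, now end at a limit rather than a number, leaving ethoxy in compound 2 as the only group on this carbonyl carbon with a readable value: the limit of > 30000 nM in this assay, at which 2 of the 4 values shown sit. The step from compound 1 to compound 4 cannot be read, as both values are limits, so these two groups cannot be ranked.

Still open, on these data alone, is whether any group other than ethoxy keeps a readable value here, such as methoxy, the hydroxyl of a carboxylic acid or an open-chain dimethylamino group. Also open, as far as these compounds go, is how an ethoxycarbonyl end would read on the saturated chain of compound 3.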